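This account rests on a few compounds, and the source may have more. Where it says the series, first, only, none or still open, it means among the compounds named here.

Measured in a functional assay on the whole organism (strain albino) for inhibition, with Rattus norvegicus as the target, read by paw edema, with stated times of 1 h and 2 h, at a dose of 100 mg/kg by the oral route; on this read-out higher numbers stand for more inhibition at the one dose given (going by the name of the read-out) and lower numbers for less inhibition:

Compound 1, `N#Cc1c(-c2ccc(O)cc2)nc(SCC(=O)Nn2c(COc3ccc(Cl)cc3Cl)nc3ccccc3c2=O)[nH]c1=O`: 68.4%
Compound 2, `N#Cc1c(-c2ccc(Cl)cc2)nc(SCC(=O)Nn2c(COc3ccc(Cl)cc3Cl)nc3ccccc3c2=O)n(Cc2ccccc2)c1=O`: 77.2%

Of the compounds shown here, two sharing one core have been tested so far. Compound 2 gives the larger of the two numbers in this assay, but compound 1 sits only a little lower, and a gap of that size lies within the ordinary scatter of repeated measurements, so the two cannot be told apart. No single-point change between measured compounds is available, and compound 1 and compound 2 differ in more than one place.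

The unmeasured compound 3, `N#Cc1c(-c2ccc(O)cc2)nc(SCC(=O)Nn2c(COc3ccc(Cl)cc3Cl)nc3ccccc3c2=O)n(Cc2ccccc2)c1=O`, is reached from compound 2 by one change: hydroxy in place of chloro on an aromatic carbon. Among the measured compounds shown here, with no measured step of this kind to lean on, the expectation for this assay is a step of no more than the scatter, in either direction, with a slight lean downward. The expected step from compound 2 to compound 3 is a number 6.2 percentage points lower from compound 2 to compound 3 (within the scatter). In this assay compound 3 is expected to give 71%, most likely between 58% and 84%.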

Compound 3, a percentage reported as inhibition, in the whole organism at one dose (the size of the read-out at that dose, not a potency): 56.1%
The estimate for compound 3 lay 14.9 percentage points above the measured number; measured number outside the range, below it.
By their numbers in this assay, from the lowest: compound 3; then compounds 1 and 2 (each within the scatter of the next).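

Among the compounds shown here, the swap of 4-chlorophenyl to 4-hydroxyphenyl on the benzyl-bearing core is the first change here seen on its own, and in this assay it gives a number 21.1 percentage points lower from compound 2 to compound 3 (beyond the scatter), so this place on the aromatic ring is not indifferent to which group it carries. The benzyl group on the aromatic nitrogen can also now be read alone: with the 4-hydroxyphenyl group held fixed, putting benzyl in place of hydrogen gives a number 12.3 percentage points lower from compound 1 to compound 3 (beyond the scatter), a change that the earlier pair could not isolate, since those two compounds differ in more than one place. No measurement at hand explains why either change moves the number in this way.

From the compounds shown here alone, it remains open whether chloro and hydroxy would differ to the same extent with hydrogen rather than benzyl on that nitrogen, and so whether the two steps simply add up or depend on each other. Going by these compounds, how an amine or a methoxy group would read at this place on the ring, or a longer chain such as phenethyl in place of benzyl, also stays unknown from these compounds.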